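A few compounds are considered here, and "the series" means these few. Any claim that something is new, unique, unknown or untested is made for them only; others in the source may bear on it.

Measured compounds:
compound 1 `Cn1nc(-c2ccc(F)cc2)cc1CO[C@@H]1COc2nc([N+](=O)[O-])cn2C1`, > 128000 nM
compound 2 `Cn1nc(-c2ccc(OC(F)(F)F)cc2)cc1CO[C@@H]1COc2nc([N+](=O)[O-])cn2C1`, > 128000 nM
compound 3 `O=[N+]([O-])c1cn2c(n1)OC[C@@H](OCc1ccn(-c3ccc(F)cc3)n1)C2`, > 128000 nM

In an ADME assay on Vero cells (Chlorocebus sabaeus) for cytotoxicity, with a stated time of 72 h (on this read-out lower numbers stand for stronger inhibition and higher numbers for weaker inhibition), compound 1 gives > 128000 nM, which is a limit of the assay and not a number. Compound 2 is made from compound 1 by trifluoromethoxy in place of fluoro on an aromatic carbon. In this assay compound 2 gives > 128000 nM, again a limit. The step that the two limits leave unreadable from compound 1 to compound 2 therefore cannot be sized. Compound 3 gives in this assay > 128000 nM, also a limit. The difference between the core of compound 3 and the core of compound 1 is not broken down here.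

Compound 4 `O=[N+]([O-])c1cn2c(n1)OC[C@@H](OCc1ccn(-c3ccc(OC(F)(F)F)cc3)n1)C2` is not yet measured. It arises from compound 3 by trifluoromethoxy in place of fluoro on an aromatic carbon, the same change as from compound 1 to compound 2, at a place described in the same words. The expectation for compound 4 rests on (the limit of > 128000 nM in this assay, at which 3 of the 3 values shown sit). Given that compound 2 shows > 128000 nM after the same change, compound 4 is expected to remain unreadable in this assay, with a step that the limit leaves unreadable from compound 3 to compound 4. The estimate for compound 4 is 160000 nM, between 64000 nM and 400000 nM, most likely reported again only as a limit.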

Compound 4, half-maximal inhibitory concentration: > 128000 nM
Compound 4 was reported as a limit (the forecaster's own chance of this, stated with the estimate: 85%); the middle value does not contradict the limit.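

In this assay compound 4 gives > 128000 nM, which is a limit of the assay and not a number. Among the compounds shown here, compound 3 also stands at a limit, so no step between compound 3 and compound 4 can be read, and the same holds across the series: the limit of > 128000 nM in this assay, at which 4 of the 4 values shown sit. The compounds shown leave open whether trifluoromethoxy in place of fluoro changes this read-out at all.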